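A few compounds are considered here, and "the series" means these few. Any claim that something is new, unique, unknown or untested is made for them only; others in the source may bear on it.

Series in an ADME assay on HepG2 cells (Homo sapiens) for cytotoxicity; on this read-out lower numbers stand for higher toxicity in this test and higher numbers for lower toxicity in this test:
- compound 1 `CSc1cccc(N2C(=O)c3ccc(-c4ccco4)n3CC2(C)C(=O)NC2CCCC2)c1`: > 50000 nM, a limit
- compound 2 `CSc1cccc(N2C(=O)CN(c3ccccc3)CC2(C)C(=O)NC2CCCC2)c1`: > 50000 nM, a limit
- compound 3 `CSc1cccc(N2C(=O)CN(c3cccc(C(F)(F)F)c3)CC2C(=O)NC2CCCC2)c1`: 20000 nM
- compound 4 `CSc1cccc(N2C(=O)CN(c3cccc(C#N)c3)CC2C(=O)NC2CCCC2)c1`: not yet measured

Going by the values given here, compound 3 gives the only actual number, 20000 nM. Compound 1 and compound 2 sit at the limit of > 50000 nM in this assay, at which 2 of the 3 values shown sit.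

Compound 4 differs from compound 3 at one place: cyano in place of trifluoromethyl on an aromatic carbon. Among the compounds with values here, no measured pair isolates this exchange, so only a small move in this assay is expected, if any, leaning towards a higher number and so lower toxicity. The expected change is a 1.5-fold higher number from compound 3 to compound 4 (0.18 log units; within the scatter). Compound 4 is estimated at 30000 nM, with an expected range of 13000 nM to 60000 nM.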

Compound 4, half-maximal cytotoxic concentration: > 50000 nM
Compound 4 was reported as a limit; the forecaster's own chance of this, stated with the estimate: 30%; middle value at least 1.6-fold (0.22 log units) away from the limit.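

In this assay, going by these compounds alone, cyano in place of trifluoromethyl on this aromatic carbon gives an at least 2.5-fold higher number from compound 3 to compound 4 (0.39 log units; beyond the scatter), the first comparison that isolates a single change. It shows that the read-out responds to the group at this position. Compound 4 gives a limit, so the step has no upper size and the full extent of the change stays unknown: the limit of > 50000 nM in this assay, at which 3 of the 4 values shown sit.

On these data alone, whether an amine or a carboxylic acid at this position would give a number or also reach the limit remains open. No order can be read among the compounds at the limit.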